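Longer alkyl chains against the mitochondrial helicase

The source may hold more compounds than are shown below. What is called first, only, known or untested is meant among the compounds shown, and "the series" means these compounds.

Measured so far:
compound 1 `CCCCCCCCCCCCNc1nc(O)c2ncnc-2c(O)n1` — only a limit in an assay on isolated protein for inhibition of ATP-dependent RNA helicase SUPV3L1, mitochondrial (Homo sapiens) (a higher number here means a weaker inhibitor, a lower number a stronger inhibitor), > 500 ug/mL
compound 2 `CCCCCCCCCCCCCCNc1nc(=O)c2ncn([C@@H]3O[C@H](CO)[C@@H](O)[C@H]3O)c2c(=O)[nH]1` — 300 ug/mL in this assay
compound 3 `CCCCCCCCCCCCCCCCNc1nc(=O)c2ncn([C@@H]3O[C@H](CO)[C@@H](O)[C@H]3O)c2c(=O)[nH]1` — only a limit, > 500 ug/mL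

Compound 3 stands at the ceiling of this assay, its > 500 ug/mL being a limit and not a number. Two of the three values sit there, see (the limit of > 500 ug/mL in this assay, at which 2 of the 3 values shown sit). Compound 4 `CCCCCCCCCCCCCCCCCCNc1nc(=O)c2ncn([C@@H]3O[C@H](CO)[C@@H](O)[C@H]3O)c2c(=O)[nH]1` differs from compound 3 by ethyl in place of hydrogen on a saturated chain carbon, ten or more bonds along the chain from a nitrogen on an aromatic ring. Going by the values given here, the one step bearing on this change is an at least 1.6-fold higher number from compound 2 to compound 3 (0.22 log units; that floor lies within the scatter), the same extension one rung earlier, which ran into the limit. In this assay the step expected is therefore a step that the limit leaves unreadable from compound 3 to compound 4, that is, no measurable inhibition. Compound 4 is expected at 700 ug/mL, between 300 ug/mL and 2000 ug/mL, most likely again reported only as a limit.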

Compound 4, half-maximal inhibitory concentration: > 500 ug/mL
Compound 4 ended at the assay's limit (the forecaster's own chance of this, stated with the estimate: 80%); the middle value is on the limit's open side.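

The step from compound 3 to compound 4 cannot be read, since both values are limits. In this assay, butyl in place of hydrogen on the saturated chain carbon gives an at least 1.6-fold higher number from compound 2 to compound 4 (0.22 log units; that floor lies within the scatter), so a further chain extension adds no measurable inhibition. Compound 2 remains the only compound shown with a number and not a limit, and the series now rests mostly on the ceiling: the limit of > 500 ug/mL in this assay, at which 3 of the 4 values shown sit.

From the compounds shown here alone, the true values of compound 3 and compound 4 stay open. So does whether a chain ending in an amine or a carboxylic acid on the same core would give a number under the limit.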